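Swapping a dichlorobenzyl for a methoxybenzyl on a diaminoquinoxaline

This account rests on a few compounds, and the source may have more. Where it says the series, first, only, none or still open, it means among the compounds named here.

Of the compounds shown here, two have been measured in a functional assay on CCRF-CEM cells (Homo sapiens) for inhibition, read by sulforhodamine B assay, with a stated time of 48 h; on this read-out higher numbers stand for weaker inhibition of growth and lower numbers for stronger inhibition of growth. Compound 1 `Nc1cc(N)c2nc(-c3ccccc3)c(NCc3ccc(Cl)c(Cl)c3)nc2c1` gives 132 nM in this assay, and compound 2 `CCOC(=O)[C@H](CCC(=O)O)NC(=O)c1ccc(CNc2nc3cc(N)cc(N)c3nc2-c2ccccc2)cc1` gives 22900 nM. Compound 1 therefore stands at the lower of the two numbers, the stronger inhibitor of growth, with compound 2 far above it and well beyond the scatter of repeated measurements.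

The unmeasured compound 3 `COc1ccc(CNc2nc3cc(N)cc(N)c3nc2-c2ccccc2)cc1` keeps the shared core of compound 1 and differs from it in one place: 4-methoxyphenyl in place of 3,4-dichlorophenyl on a saturated chain carbon bound to a nitrogen on an aromatic ring. The difference can also be read as 3,4-dichlorobenzyl to 4-methoxybenzyl on a saturated chain carbon bound to a nitrogen on an aromatic ring.

Among the measured compounds shown here, no step between two measured compounds that differ in only this place is available, so the size of the change is estimated rather than read off. The expectation is a moderate rise in the number, that is a weakening, as the estimated step of a 3.8-fold higher number from compound 1 to compound 3 (0.58 log units; beyond the scatter) expresses. Compound 3 is expected to give about 500 nM in this assay, with a range from 130 nM to 2500 nM.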

Compound 3, concentration for 50% growth inhibition: 3390 nM
For compound 3 the middle estimate is 6.8-fold (0.83 log units) below the measured one, and the stated range ends below it.
By their numbers in this assay, from the lowest: compound 1; then compound 3; then compound 2.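

In this assay the place on a saturated chain carbon bound to a nitrogen on an aromatic ring proves sensitive to the group it carries: 4-methoxyphenyl in place of 3,4-dichlorophenyl gives a 26-fold higher number from compound 1 to compound 3 (1.41 log units; beyond the scatter) and so a large weakening of growth inhibition. Among the compounds shown here, this is the first step that can be read at this place, and it shows that two groups with the same count of heavy atoms, each holding one six-membered aromatic ring of carbon only, are far from interchangeable here. No measurement shown bears on what lies behind this step, so it stands without an explanation.

The compounds shown do not separate the loss of the two chlorines from the gain of the methoxy group, and a plain phenyl or a phenyl with a single chlorine would be needed to tell these apart. From the compounds shown here alone, it also remains open how this place responds to other kinds of group, such as a ring bearing an amine or a carboxylic acid, or a longer chain between the nitrogen and the ring.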